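A Difluorobenzyl Amide Follows Two Compounds at the Limit

This account rests on a few compounds, and the source may have more. Where it says the series, first, only, none or still open, it means among the compounds named here.

The three measured compounds share one core and differ only in the group carried on the amide-type nitrogen. Compound 1 `COc1ccc2c(=O)c(/C=C/C(=O)Nc3ccccc3)coc2c1` bears an unsubstituted phenyl there, and in a functional assay on A549 cells (Homo sapiens) for inhibition, read by MTT assay, with a stated time of 48 h (on this read-out lower numbers stand for stronger inhibition and higher numbers for weaker inhibition), compound 1 gives 51000 nM. Compound 2 `CCOc1ccc(NC(=O)/C=C/c2coc3cc(OC)ccc3c2=O)cc1` is reported in this assay only as a limit, > 100000 nM. Compound 3 `COc1ccc2c(=O)c(/C=C/C(=O)Nc3cccc(C)c3)coc2c1` likewise reaches only a limit in this assay, > 100000 nM. The step of an at least 1.9-fold higher number from compound 1 to compound 2 (0.29 log units; that floor lies within the scatter) and the step of an at least 1.9-fold higher number from compound 1 to compound 3 (0.29 log units; that floor lies within the scatter) are each a floor that lies within the scatter, and the step that the two limits leave unreadable from compound 2 to compound 3 cannot be read at all. Compound 3 thus stands at the limit of > 100000 nM in this assay, at which 2 of the 3 values shown sit.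

Compound 4 `COc1ccc2c(=O)c(/C=C/C(=O)NCc3ccc(F)cc3F)coc2c1` alters the amide substituent: 2,4-difluorobenzyl in place of 3-methylphenyl on an amide-type nitrogen. Within the data shown here, no measured step exchanges an aryl group for a benzyl group on the amide-type nitrogen, so the only guidance comes from the two floors measured from compound 1 and the unreadable step between compound 2 and compound 3, none of which show a group that lifts the number above the scatter. Compound 4 is therefore expected to give about 80000 nM in this assay, with a range from 20000 nM to 300000 nM. That estimate corresponds to an expected step of an at least 1.2-fold lower number from compound 3 to compound 4 (0.09 log units; that floor lies within the scatter), which sits within the scatter.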

Compound 4, half-maximal inhibitory concentration: 13300 nM
Compound 4: the middle estimate sits 6.0-fold (0.78 log units) above what was measured, and the stated range ends above it.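

In this assay, this position on the amide-type nitrogen now shows a change that reaches beyond the scatter: 2,4-difluorobenzyl in place of 3-methylphenyl gives an at least 7.5-fold lower number from compound 3 to compound 4 (0.87 log units; beyond the scatter), and 2,4-difluorobenzyl in place of 4-ethoxyphenyl gives an at least 7.5-fold lower number from compound 2 to compound 4 (0.87 log units; beyond the scatter). Both of these steps are floors, resting on a limit of the assay for compound 2 and for compound 3: the limit of > 100000 nM in this assay, at which 2 of the 4 values shown sit. Among these compounds, the one step with a measured value at both ends is 2,4-difluorobenzyl in place of phenyl, a 3.8-fold lower number from compound 1 to compound 4 (0.58 log units; beyond the scatter), so compound 4 carries the lowest number of the four, with its steps to all three others beyond the scatter, where the earlier compounds offered only floors within it.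

The compounds shown leave open whether the lower number goes with the benzyl form of the group or with its two fluorines, a question that an unsubstituted benzyl or a 4-fluorophenyl group on the same nitrogen would separate. Also open, from the compounds shown here alone, is how a longer chain such as 2-phenylethyl, or a saturated group such as cyclohexylmethyl, would read at this position.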